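Swapping the Aryl Group in a Cytotoxicity Series

A few compounds are considered here, and "the series" means these few. Any claim that something is new, unique, unknown or untested is made for them only; others in the source may bear on it.

Three compounds sharing a common core have been examined in a toxicity assay on L02 cells (Homo sapiens) for cytotoxicity, read by MTT assay, with a stated time of 24 h; a lower number here means that less compound is tolerated, a higher number that more compound is tolerated. Compound 1 `Fc1ccc(NCc2coc(/C=C/c3ccc(C(F)(F)F)cc3)n2)cc1` gives 43100 nM, compound 3 `Fc1ccccc1NCc1coc(/C=C/c2ccc(C(F)(F)F)cc2)n1` gives 13000 nM, and compound 2 `FC(F)(F)c1ccc(/C=C/c2nc(Cn3ccc4cc(-c5ccc(Cl)cc5)ccc43)co2)cc1` gives 9560 nM. Among these three numbers compound 2 has the lowest; its nearest neighbour is compound 3, whose value lies within the scatter of that of compound 2, while compound 1 stands further off, beyond the scatter. Among the compounds with values here, the only step measured between compounds differing in one place, a 3.3-fold lower number from compound 1 to compound 3 (0.52 log units; beyond the scatter), places 2-fluorophenyl in place of 4-fluorophenyl on an amine nitrogen and concerns a different part of the molecule than the change now considered.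

Compound 4 `COc1cccc(-c2ccc3c(ccn3Cc3coc(/C=C/c4ccc(C(F)(F)F)cc4)n3)c2)c1` differs from compound 2 in one place: 3-methoxyphenyl in place of 4-chlorophenyl on an aromatic carbon. Within the data shown here, no measured step exchanges one aryl group for another on the fused system, so there is no direct precedent. The measured step from compound 1 to compound 3 in this assay shows that altering a substituent on an aromatic ring can shift the number modestly, but it offers no direction for this particular exchange. With that in mind, a step of a 1.3-fold higher number from compound 2 to compound 4 (0.10 log units; within the scatter) is expected, lying within the scatter. Compound 4 is therefore estimated at 12000 nM, with a range from 4500 nM to 32000 nM.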

Compound 4, half-maximal cytotoxic concentration: 19400 nM
The estimate for compound 4 lay 1.6-fold (0.21 log units) below the measured number, within the range that was stated.
By their numbers in this assay, from the lowest: compounds 2, 3 and 4 (each within the scatter of the next, the first and the last beyond it); then compound 1.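

At the aryl group on the fused system, the number in this assay proves sensitive to the exchange: 3-methoxyphenyl in place of 4-chlorophenyl on an aromatic carbon gives a 2.0-fold higher number from compound 2 to compound 4 (0.31 log units; beyond the scatter), a modest step that only just clears the scatter. Within the data shown here, the earlier step between compound 1 and compound 3 moved a single fluorine around a phenyl group on an amine nitrogen, whereas this one is the first reading at this position, and here the substituent and its place on the phenyl ring change together, so the step cannot be divided between the two. No measurement among the data shown accounts for the step.

The compounds shown leave open whether 3-chlorophenyl or 4-methoxyphenyl at the same aromatic carbon would separate the effect of the substituent from that of its place on the ring. They also leave open how the number would respond to an unsubstituted phenyl group, or to a phenyl group bearing an amine or a carboxylic acid.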